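Swapping an Ester for a Propargyl Ether on a Fluorinated Core

This account rests on a few compounds, and the source may have more. Where it says the series, first, only, none or still open, it means among the compounds named here.

Of the compounds shown here, three have been measured in an assay on isolated protein (Echinochloa esculenta) for inhibition of protoporphyrinogen oxidase, chloroplastic (Oryza sativa subsp. japonica), using a Dixon plot, with a stated time of 5 min; a lower number here means a stronger inhibitor, a higher number a weaker inhibitor. Compound 1 `C#CCOc1cc(N2C(=O)C3=C(CCCC3)C2=O)ccc1Cl` gives 0.794 nM, compound 2 `CC(C)OC(=O)c1cc(N2C(=O)C3=C(CCCC3)C2=O)ccc1Cl` gives 2 nM, and compound 3 `CC(C)OC(=O)c1cc(N2C(=O)C3=C(CCCC3)C2=O)c(F)cc1Cl` gives 7.94 nM. The change propargyloxy in place of isopropoxycarbonyl on an aromatic carbon gave a 2.5-fold lower number from compound 2 to compound 1 (0.40 log units; beyond the scatter). The cores of compound 3 and compound 2 differ by fluoro in place of hydrogen on an aromatic carbon, which gave a 4.0-fold higher number from compound 2 to compound 3 (0.60 log units; beyond the scatter). Compound 4 `C#CCOc1cc(N2C(=O)C3=C(CCCC3)C2=O)c(F)cc1Cl` is not yet measured; it differs from compound 3 by propargyloxy in place of isopropoxycarbonyl on an aromatic carbon. This is the same kind of change as that from compound 2 to compound 1, but not the same, since here the place is also para to a fluoro group. The expected step in this assay is a 2.5-fold lower number from compound 3 to compound 4 (0.39 log units; beyond the scatter), resting on the step of a 2.5-fold lower number from compound 2 to compound 1 (0.40 log units; beyond the scatter) seen before. Compound 4 is estimated at 3.2 nM, within 1.3 nM to 8 nM.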

Compound 4, half-maximal inhibitory concentration: 3.16 nM
Beside the measured number, compound 4's estimate is 1.0-fold (0.01 log units) above it; the measured number falls inside the stated range.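

In this assay, propargyloxy in place of isopropoxycarbonyl gives a 2.5-fold lower number from compound 3 to compound 4 (0.40 log units; beyond the scatter), which matches the step seen on the core without the fluoro group: the same change on two cores in this assay, a 2.5-fold lower number (0.40 log units; beyond the scatter) from compound 2 to compound 1 and a 2.5-fold lower number (0.40 log units; beyond the scatter) from compound 3 to compound 4, 1.0-fold (0.00 log units) apart, within the scatter of two such steps. Fluoro in place of hydrogen gives a 4.0-fold higher number from compound 1 to compound 4 (0.60 log units; beyond the scatter), which also matches its earlier step: the same change on two cores in this assay, a 4.0-fold higher number (0.60 log units; beyond the scatter) from compound 2 to compound 3 and a 4.0-fold higher number (0.60 log units; beyond the scatter) from compound 1 to compound 4, 1.0-fold (0.00 log units) apart, within the scatter of two such steps. In these four compounds, each change therefore carried over from one core to the other with its size intact, but this rests on just two cores in one assay and shows neither why the steps match nor whether they would hold on a third core.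

Going by these compounds, it remains open whether an amine, a carboxylic acid or a longer ether chain in place of propargyloxy would follow the same pattern. On these data alone, it is also open whether the propargyloxy step would keep its size with a methoxy group in place of the fluoro group.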